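A few compounds are considered here, and "the series" means these few. Any claim that something is new, unique, unknown or untested is made for them only; others in the source may bear on it.

Compound 1 `CCCc1cc(N)c2cc(NC(=O)/C=C/c3ccc(F)cc3)ccc2n1` gives 130 nM in an assay on isolated protein for displacement of a labelled ligand from melanin-concentrating hormone receptor 1 (Homo sapiens); on this read-out lower numbers stand for stronger inhibition and higher numbers for weaker inhibition. Compound 2 `CCCc1cc(N)c2cc(NC(=O)/C=C/c3ccccc3Cl)ccc2n1` gives 120 nM. Compound 3 `CCCc1cc(N)c2cc(NC(=O)/C=C/c3ccc(I)cc3)ccc2n1` gives 2.3 nM.

Compound 3 stands lowest of the three numbers, and both of its neighbours lie far off: the step of a 52-fold lower number from compound 2 to compound 3 (1.72 log units; beyond the scatter) and the step of a 57-fold lower number from compound 1 to compound 3 (1.75 log units; beyond the scatter) are each large and beyond the scatter. Compound 4 `CCCc1cc(N)c2cc(NC(=O)/C=C/c3ccc(Cl)c(Cl)c3)ccc2n1` differs from compound 3 in a single place: 3,4-dichlorophenyl in place of 4-iodophenyl on a double-bonded chain carbon bound to a double-bonded chain carbon. Within the data shown here, two measured steps bear on this change. The step of a 57-fold lower number from compound 1 to compound 3 (1.75 log units; beyond the scatter) shows that exchanging one halogen for another on this aromatic ring can move this assay a great deal, with iodo far ahead of fluoro. The step of a 1.1-fold lower number from compound 1 to compound 2 (0.03 log units; within the scatter), which moves a halogen to another spot on the ring, stays within the scatter. Among the measured compounds shown here, no measured compound carries chloro on this ring, and none carries two halogens, so the dichloro pattern has no direct precedent here. Because fluoro and iodo sit so far apart in a 57-fold lower number from compound 1 to compound 3 (1.75 log units; beyond the scatter), chloro is expected to land between them, and compound 4 is therefore expected to show a moderate rise in this assay, a 4.3-fold higher number from compound 3 to compound 4 (0.64 log units; beyond the scatter). Compound 4 is estimated at 10 nM, within a range from 3 nM to 40 nM.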

Compound 4, half-maximal inhibitory concentration: 60 nM
Compound 4: the middle estimate sits 6.0-fold (0.78 log units) below what was measured; measured number above the stated range.
By their numbers in this assay, from the lowest: compound 3; then compounds 4, 2 and 1 (each within the scatter of the next, the first and the last beyond it).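

In this assay, the step of a 26-fold higher number from compound 3 to compound 4 (1.42 log units; beyond the scatter) shows that two chlorine atoms on this ring do not stand in for the single iodine of the 4-iodophenyl group. The step of a 2.2-fold lower number from compound 1 to compound 4 (0.34 log units; beyond the scatter) is only modest and the step of a 2.0-fold lower number from compound 2 to compound 4 (0.30 log units; within the scatter) stays within the scatter, so the 3,4-dichlorophenyl group falls in with the 4-fluorophenyl and 2-chlorophenyl groups, and among these four compounds a halogen on the ring does not by itself give a low number: only compound 3 stands apart. Nothing measured on these compounds speaks to why the iodo compound is set apart in this way.

On these data alone, how a 4-chlorophenyl or 4-bromophenyl group on the same double-bonded chain carbon would compare remains open, so the effect of which halogen is present cannot yet be fully separated from the effect of how many there are and where they sit. Also open, as far as these compounds go, is whether a halogen is needed at all, or whether a ring carrying a methoxy group or a short carbon chain such as ethyl could come close to compound 3.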